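Sulfonamide series: methyl sulfonyl in place of arylsulfonyl

A few compounds are considered here, and "the series" means these few. Any claim that something is new, unique, unknown or untested is made for them only; others in the source may bear on it.

Measured in an assay on isolated protein for inhibition of malate dehydrogenase, mitochondrial (Sus scrofa), with stated times of 45 min and 30 min; a higher number here means a weaker inhibitor, a lower number a stronger inhibitor:
compound 1 `O=S(=O)(Nc1ccc2oc(-c3ccccc3)nc2c1)c1ccc(Cl)cc1` — > 63000 nM, a limit of the assay
compound 2 `O=S(=O)(Nc1ccc2oc(-c3ccccc3)nc2c1)c1ccc(Cl)c(C(F)(F)F)c1` — > 63000 nM, a limit of the assay
compound 3 `O=S(=O)(Nc1ccc(-c2nc3ccccc3o2)cc1)c1ccccc1F` — > 63000 nM, a limit of the assay

Compound 1 stands only at a limit of this assay, with no number for it. Going by the values given here, the one step that can be drawn among measured compounds, a step that the two limits leave unreadable from compound 1 to compound 2, cannot be sized because of the limit of > 63000 nM in this assay, at which 3 of the 3 values shown sit. Among the compounds with values here, compound 3 carries the sulfonamide on the other side of the shared core and also sits at the limit, so no pair of measured values gives a readable step.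

Compound 4 `CS(=O)(=O)Nc1ccc2oc(-c3ccccc3)nc2c1` differs from compound 1 in one place: methyl in place of 4-chlorophenyl on a sulfonyl sulfur. Within the data shown here, no measured step touches the sulfonyl substituent, so nothing in this assay says how far a change there moves the read-out; the only pattern in the measured set is that every value stops at the limit, and compounds 1, 2 and 3 all sit there.

For compound 4 the estimate in this assay is 80000 nM, expected to lie between 30000 nM and 250000 nM. The expected step is a step that the limit leaves unreadable from compound 1 to compound 4, most likely again reported as a limit rather than a number.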

Compound 4, half-maximal inhibitory concentration: > 63000 nM
Compound 4 ended at the assay's limit; the forecaster's own chance of this, stated with the estimate: 85%; the middle value does not contradict the limit.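

Compound 1 and compound 4 both stop at a limit of this assay, so no step can be read for methyl in place of 4-chlorophenyl on a sulfonyl sulfur: the limit of > 63000 nM in this assay, at which 4 of the 4 values shown sit.

The compounds shown leave open whether any change to the sulfonyl substituent or the shared core gives a readable value in this assay.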